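From formylphenyl to naphthalen-1-yl in a cell growth assay

A few compounds are considered here, and "the series" means these few. Any claim that something is new, unique, unknown or untested is made for them only; others in the source may bear on it.

Measured so far:
compound 1 `CCc1ccc(-c2cn3ccnc3c(-c3ccc4ncn(Cc5ccccc5)c4c3)n2)cc1`: 14.8%
compound 2 `O=Cc1ccc(-c2cn3ccnc3c(-c3ccc4ncn(Cc5ccccc5)c4c3)n2)cc1`: 27.8%

Of the compounds shown here, two have been tested in a functional assay on SK-MEL-2 cells (Homo sapiens) for inhibition, read by sulforhodamine B assay, with a stated time of 48 h, tested at 10 uM; a higher number here means more inhibition at the concentration tested (going by the name of the read-out), a lower number less inhibition. Compound 1 gives 14.8% there, and compound 2 gives 27.8%, the higher of the two numbers. Going by the values given here, the single step linking them, a number 13 percentage points higher from compound 1 to compound 2 (beyond the scatter), lies beyond the scatter.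

Compound 3 `c1ccc(Cn2cnc3ccc(-c4nc(-c5cccc6ccccc56)cn5ccnc45)cc32)cc1` has not yet been measured. It differs from compound 2 in one place: naphthalen-1-yl in place of 4-formylphenyl on an aromatic carbon. Among the compounds with values here, no measured step bears directly on this exchange; the only known step, a number 13 percentage points higher from compound 1 to compound 2 (beyond the scatter), altered a small substituent on the same phenyl ring rather than replacing the ring itself. Since that step put the formyl-bearing compound 2 modestly ahead of compound 1, and compound 3 carries no formyl, a fall of similar size back toward the level of compound 1 is expected, with wide uncertainty. Compound 3 is therefore estimated at 18%, between 5% and 35%, an expected step of a number 9.8 percentage points lower from compound 2 to compound 3 (within the scatter) in this assay.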

Compound 3, a percentage reported as inhibition, at one concentration (the size of the read-out at that concentration, not a potency): 17%
For compound 3 the middle estimate is 1 percentage points above the measured one; measured number inside the range.
By their numbers in this assay, from the lowest: compounds 1 and 3 (each within the scatter of the next); then compound 2.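

Going by these compounds alone, exchanging 4-formylphenyl for naphthalen-1-yl brings a number 10.8 percentage points lower from compound 2 to compound 3 (beyond the scatter) in this assay and shows for the first time what replacing the whole ring on this aromatic carbon does, where the earlier step changed only a substituent on the phenyl ring. Exchanging 4-ethylphenyl for naphthalen-1-yl brings a number 2.2 percentage points higher from compound 1 to compound 3 (within the scatter) and so no readable change, which leaves compound 2 as the only one of the three that stands apart, while the second aromatic ring of compound 3 brings no gain over compound 2. No evidence is available on the reason for either step.

The compounds shown leave open whether the higher number of compound 2 is specific to the formyl group or would also appear with a carboxylic acid or a hydroxymethyl group on the same phenyl ring. They also leave open how an amine on that ring or a naphthalen-2-yl group at this position would compare.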